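Working notes: methyl in place of methoxy

A few compounds are considered here, and "the series" means these few. Any claim that something is new, unique, unknown or untested is made for them only; others in the source may bear on it.

In a functional assay on LoVo cells (Homo sapiens) for inhibition, read by MTT assay, with a stated time of 24 h (on this read-out lower numbers stand for stronger inhibition and higher numbers for weaker inhibition), three compounds sharing one core differ in the aryl group on an aromatic nitrogen. Compound 1 `CC1(C)[C@H]2CC[C@]1(C)N(Cc1cn(-c3ccc(F)cc3)nn1)C(=O)C2`, with 4-fluorophenyl, gives 40 nM. Compound 2 `CC1(C)[C@H]2CC[C@]1(C)N(Cc1cn(-c3ccccc3Cl)nn1)C(=O)C2`, with 2-chlorophenyl, gives 190 nM. Compound 3 `COc1ccccc1-n1cc(CN2C(=O)C[C@@H]3CC[C@@]2(C)C3(C)C)nn1`, with 2-methoxyphenyl, gives 70 nM. Compound 3 therefore lies within the scatter of compound 1 and has a lower number than compound 2, beyond the scatter.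

Compound 4 `Cc1ccccc1-n1cc(CN2C(=O)C[C@@H]3CC[C@@]2(C)C3(C)C)nn1` has methyl in place of methoxy on an aromatic carbon, ortho to a large group: methyl in place of methoxy on an aromatic carbon. Among the compounds with values here, no measured step makes this exact change. The closest is a 2.7-fold lower number from compound 2 to compound 3 (0.43 log units; beyond the scatter), a modest step that swaps chloro for methoxy at the same place. Also relevant are a 1.8-fold higher number from compound 1 to compound 3 (0.24 log units; within the scatter), which stays within the scatter, and a 4.8-fold higher number from compound 1 to compound 2 (0.68 log units; beyond the scatter), a modest step beyond it. These steps suggest only a small change, with compound 4 expected to fall in the span set by compound 3 and compound 2. The expected step is a 1.6-fold higher number from compound 3 to compound 4 (0.20 log units; within the scatter), a slightly higher number that probably stays within the scatter. For compound 4 the estimated value is 110 nM, with an expected range from 50 nM to 250 nM.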

Compound 4, half-maximal inhibitory concentration: 80 nM
Estimate against measurement, compound 4: 1.4-fold (0.14 log units) above; measured number inside the range.
By their numbers in this assay, from the lowest: compounds 1, 3 and 4 (each within the scatter of the next); then compound 2.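

In this assay, methyl in place of methoxy on this aromatic carbon, ortho to a large group, gives a 1.1-fold higher number from compound 3 to compound 4 (0.06 log units; within the scatter) and so removes the oxygen and the hydrogen-bond acceptor of methoxy with no change beyond the scatter, something the chloro to methoxy step could not show. Chloro now stands apart from both of the other groups at this place, with a 2.4-fold lower number from compound 2 to compound 4 (0.38 log units; beyond the scatter) read alongside a 2.7-fold lower number from compound 2 to compound 3 (0.43 log units; beyond the scatter), while 2-methylphenyl joins 2-methoxyphenyl in lying within the scatter of 4-fluorophenyl, with a 2.0-fold higher number from compound 1 to compound 4 (0.30 log units; within the scatter) as the printed step. No measurement at hand bears on why chloro parts from methyl and methoxy at this place.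

The compounds shown leave open how an amine or a carboxylic acid would read on this aromatic carbon, as only methoxy, methyl and chloro occupy it here. Also open, going by these compounds, is whether the match between methyl and methoxy would extend to a longer chain such as ethoxy, or would hold with either group placed elsewhere on the ring.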